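Swapping the morpholine for pyrrolidine on the thiourea

The source may hold more compounds than are shown below. What is called first, only, known or untested is meant among the compounds shown, and "the series" means these compounds.

Compound 2 `Cc1cccc(/C(N)=N/NC(=S)N2CCOCC2)n1` gives 30.2% in a functional assay on A-375 cells (Homo sapiens) for cytotoxicity, read by MTT assay, with a stated time of 72 h, tested at 1 uM (a lower number here means less inhibition of growth, a higher number more inhibition of growth at the concentration tested), the second highest of three numbers. Compound 1 `N/C(=N\NC(=S)N1CCOCC1)c1ccccn1` gives 26.8%, and the step of a number 3.4 percentage points higher from compound 1 to compound 2 (within the scatter) lies within the scatter. For the measured compounds named here, compound 3 `N/C(=N\NC(=S)N1CCSCC1)c1ccc(F)cn1` gives 55.1%, beyond the scatter above compound 2, but it differs from compound 2 in more than one place, so no single step can be drawn from it. Compound 4 `Cc1cccc(/C(N)=N/NC(=S)N2CCCC2)n1` carries pyrrolidin-1-yl in place of morpholin-4-yl on a thiocarbonyl carbon. Going by the values given here, no measured step touches this exchange; the only measured step, a number 3.4 percentage points higher from compound 1 to compound 2 (within the scatter), concerns a different position and was small. Without a bearing step, compound 4 is expected to show a step of a number 4.8 percentage points higher from compound 2 to compound 4 (within the scatter) in this assay, not clearly beyond the scatter. Compound 4 is therefore estimated at 35%, within 18% to 55%.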

Compound 4, percent growth inhibition at one concentration: 13.6%
Compound 4: the middle estimate sits 21.4 percentage points above what was measured, and the stated range ends above it.
By their numbers in this assay, from the lowest: compound 4; then compounds 1 and 2 (each within the scatter of the next); then compound 3.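

In this assay the exchange of morpholin-4-yl for pyrrolidin-1-yl on the thiocarbonyl carbon gives a step of a number 16.6 percentage points lower from compound 2 to compound 4 (beyond the scatter) and so shows that this position responds, whereas the earlier methyl exchange on an aromatic carbon stayed within the scatter. The result rests on this single pair of compounds. No evidence at hand accounts for the step. The compounds shown leave open whether ring size or the ring oxygen of morpholin-4-yl carries the difference. Going by these compounds, how a piperidin-1-yl or dimethylamino group would read on the same carbon also remains open.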